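Carbamate in place of carboxamide on the pyrazole of compound 2

The source may report more compounds than this note shows. Statements on the series, on what has been measured and on what is new or still open speak of the compounds shown alone.

Compound 1: `Cc1cc(C(=O)O)nn1C(C)c1cc(Cl)ccc1OCc1ccccc1` — 10 nM
Compound 2: `Cc1cc(C(=O)NCc2ccccn2)nn1Cc1cc(Cl)ccc1OCc1ccccc1` — 25.1 nM
Compound 3: `Cc1cc(C(N)=O)nn1Cc1cc(Cl)ccc1OCC(C)C` — 126 nM

Of the compounds shown here, three sharing a substituted five-membered core have been measured in an assay on CHO-K1 cells for displacement of a labelled ligand from prostaglandin E2 receptor EP1 subtype (Homo sapiens); a lower number here means a stronger inhibitor, a higher number a weaker inhibitor. Compound 1 gives 10 nM, compound 2 gives 25.1 nM, and compound 3 gives 126 nM. Compound 2 therefore holds the second highest of the three numbers: its nearest neighbour is compound 1, whose number is lower by a margin that lies beyond the usual scatter, and its furthest is compound 3, whose number is higher, again beyond the scatter.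

Compound 4, `Cc1cc(NC(=O)OCC(C)C)nn1Cc1cc(Cl)ccc1OCc1ccccc1`, has not yet been measured. It differs from compound 2 in one place: (isobutoxycarbonyl)amino in place of ((pyridin-2-yl)methyl)carbamoyl on an aromatic carbon. The group that enters is (isobutoxycarbonyl)amino, placed on an aromatic carbon of a five-membered aromatic ring with 2 nitrogen, next to the ring nitrogen; it carries one hydrogen-bond donor and two hydrogen-bond acceptors, as did the group it replaces, but it has no ring.

Going by the values given here, no measured pair shows this exact change, so the account rests on the spread of the three values. The expected step in this assay from compound 2 is small, on the order of the scatter, with a slight lean towards a higher number: a 1.6-fold higher number from compound 2 to compound 4 (0.20 log units; within the scatter). Compound 4 is estimated at 40 nM, within a range from 10 nM to 160 nM.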

Compound 4, half-maximal inhibitory concentration: 25.1 nM
Beside the measured number, compound 4's estimate is 1.6-fold (0.20 log units) above it; the range from low to high includes it.
By their numbers in this assay, from the lowest: compound 1; then compounds 2 and 4 (each within the scatter of the next); then compound 3.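

In this assay, placing (isobutoxycarbonyl)amino in the position of ((pyridin-2-yl)methyl)carbamoyl, on an aromatic carbon of the five-membered aromatic ring, gives no change at the digits printed from compound 2 to compound 4 (within the scatter) on the shared core. Going by these compounds alone, this is the first reading of a change made in one place alone, since the earlier compounds differed from each other in more than one place and their spread could not be assigned to this position. The pair shows that this position accepts a group with no ring and 8 heavy atoms instead of a group with a six-membered aromatic ring and 10 heavy atoms, with the counts of hydrogen-bond donors and acceptors the same in both, and the number stays within the scatter. Nothing at hand accounts for this outcome.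

From the compounds shown here alone, whether a simple amine or a sulfonamide at this place would hold the number as well remains open, as does the outcome of a longer chain in place of the isobutyl end. The carbamate link and the isobutyl end also stay unseparated, as they enter together in this single step.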